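Fluoro in place of hydrogen, compared across two rings

The source may report more compounds than this note shows. Statements on the series, on what has been measured and on what is new or still open speak of the compounds shown alone.

Compound 1 `O=C(Nc1cc(C(F)(F)F)cc(C(F)(F)F)c1)c1ccccc1O` in an ADME assay on cells (Macrophage, Mus musculus) for cytotoxicity, read by resazurin assay, with a stated time of 3 days (a lower number here means a stronger inhibitor, a higher number a weaker inhibitor), gives 12000 nM. Compound 2 `O=C(Nc1cc(C(F)(F)F)cc(C(F)(F)F)c1)c1cc(F)ccc1O` gives 2500 nM; the change fluoro in place of hydrogen on an aromatic carbon produced a 4.8-fold lower number from compound 1 to compound 2 (0.68 log units; beyond the scatter). Compound 3 `O=C(Nc1cccc(F)c1)c1cc(Cl)ccc1O` gives 15000 nM. How the core of compound 3 differs from that of compound 1 is not broken down here.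

Compound 4 `O=C(Nc1cc(F)cc(F)c1)c1cc(Cl)ccc1O` carries the change (fluoro in place of hydrogen on an aromatic carbon). This is the same kind of change as from compound 1 to compound 2, but not the same: there the entering fluoro sat para to a hydroxy group and meta to a large group, here it sits meta to a fluoro group and meta to a large group. Since the place differs, the step from compound 1 to compound 2 is only a loose guide, and the step expected here is smaller, a 1.7-fold lower number from compound 3 to compound 4 (0.22 log units; within the scatter). Compound 4 is expected to give 9000 nM in this assay, estimated between 3500 nM and 22000 nM.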

Compound 4, half-maximal inhibitory concentration: 6100 nM
Compound 4: middle estimate off by 1.5-fold (0.17 log units), on the high side; low and high end bracket the measured number.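

In this assay the fluoro change gave a 2.5-fold lower number from compound 3 to compound 4 (0.39 log units; beyond the scatter) on a second core, so the direction of the step held on both cores shown, at two different places on them. Two pairs make no rule for the series, and they do not tell what sets the size of a step. The sizes of the two steps cannot be told apart: the same change on two cores in this assay, a 4.8-fold lower number (0.68 log units; beyond the scatter) from compound 1 to compound 2 and a 2.5-fold lower number (0.39 log units; beyond the scatter) from compound 3 to compound 4, 2.0-fold (0.29 log units) apart, within the scatter of two such steps

Still open, going by these compounds, is whether an amine or a methoxy group in place of the same hydrogens would move the number the same way as fluoro. Also open, on these data alone, is whether fluoro at other places on either core would follow these two steps.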